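The source may report more compounds than this note shows. Statements on the series, on what has been measured and on what is new or still open speak of the compounds shown alone.

Measured compounds:
- compound 1 `O=C(O)Cc1sc(C(c2ccc(F)cc2)c2ccc(F)cc2)nc1-c1cc(F)cc(F)c1`: 340 nM
- compound 2 `O=C(O)Cc1sc(C(c2ccc(F)cc2)c2ccc(F)cc2)nc1-c1cn[nH]c1`: 220 nM
- compound 3 `Cc1cc(-c2nc(C(c3ccc(F)cc3)c3ccc(F)cc3)sc2CC(=O)O)ccn1`: 53 nM

All three share one core and differ only in the aromatic group attached to it. In an in vitro functional assay on HEK285-7 cells for antagonist activity at prostaglandin D2 receptor 2 (Homo sapiens), read by BRET and beta-arrestin recruitment (a lower number here means a stronger inhibitor, a higher number a weaker inhibitor), compound 3 gives the lowest number of the three, and both of its steps lie beyond the scatter: a 6.4-fold lower number from compound 1 to compound 3 (0.81 log units; beyond the scatter) and a 4.2-fold lower number from compound 2 to compound 3 (0.62 log units; beyond the scatter). Compound 3 is therefore the strongest inhibitor among the measured set, while compound 1 and compound 2 are within the scatter of each other, as a 1.5-fold lower number from compound 1 to compound 2 (0.19 log units; within the scatter) shows.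

Compound 4 `CN(C)c1cc(-c2nc(C(c3ccc(F)cc3)c3ccc(F)cc3)sc2CC(=O)O)ccn1` has not yet been measured. It keeps the pyridine-bearing side of compound 3 and changes one substituent: dimethylamino in place of methyl on an aromatic carbon. Going by the values given here, none of the measured steps concerns this kind of change; all three swap the whole aromatic group, not a substituent on it. They only show that the group in this position can move this assay by a modest amount. Among the compounds with values here, with no direct precedent, the expectation for compound 4 is a number close to compound 3, and the step of a 1.1-fold lower number from compound 3 to compound 4 (0.03 log units; within the scatter) is expected to stay within the scatter. Compound 4 is estimated at 50 nM, with a range from 20 nM to 130 nM.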

Compound 4, half-maximal inhibitory concentration: > 100000 nM
Compound 4: only a limit was reported (the forecaster's own chance of this, stated with the estimate: 2%); at least 2000-fold (3.30 log units) between middle value and limit.
By their numbers in this assay, from the lowest: compound 3; then compounds 2 and 1 (each within the scatter of the next). At a limit, above all of these: compound 4.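

Compound 4 is reported in this assay only as a limit, not as a number: the limit of > 100000 nM in this assay, at which 1 of the 4 values shown sits.

The earlier steps shown here swapped the whole aromatic group and moved the number by a modest amount at most, yet here a single substituent change on the six-membered aromatic ring with 1 nitrogen gives an at least 1800-fold higher number from compound 3 to compound 4 (3.27 log units; beyond the scatter), so this place next to the ring nitrogen proves far less forgiving than those steps suggested. The 2-(dimethylamino)pyridin-4-yl group also falls far behind the two other aromatic groups, with an at least 450-fold higher number from compound 2 to compound 4 (2.65 log units; beyond the scatter) and an at least 290-fold higher number from compound 1 to compound 4 (2.46 log units; beyond the scatter), which shows that the change erases activity rather than merely cancelling the advantage of the 2-methylpyridin-4-yl group.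

With only methyl and dimethylamino shown at this place, it remains open whether the loss belongs to the nitrogen attached to the ring or to the larger size of the group, and a plain amine, a methoxy group or an ethyl group there would help to separate the two. The compounds shown also give no reason for the drop, and they cannot say how steeply activity falls between methyl and dimethylamino.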